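A methoxy swap at a solubility limit

The source may hold more compounds than are shown below. What is called first, only, known or untested is meant among the compounds shown, and "the series" means these compounds.

In a physicochemical assay for solubility, using the shake flask method, in simulated intestinal fluid, measured as kinetic solubility, with a stated time of 2 h, at 25 degrees C, at pH 6.5 (a higher number here means a more soluble compound, a lower number a less soluble compound), compound 1 `Cc1noc(-c2nc(C)c3c(c2N)C(=O)N(Cc2ccccc2)C3=O)n1` gives < 5000 nM as a limit of the assay. Compound 2 `Cc1noc(-c2nc(C)c3c(c2N)C(=O)N(Cc2cccc(C(F)(F)F)c2)C3=O)n1` gives < 5000 nM which is also a limit, so it has no readable number. Compound 3 `COc1cccc(CN2C(=O)c3c(C)nc(-c4nc(C)no4)c(N)c3C2=O)c1` carries methoxy in place of trifluoromethyl on an aromatic carbon, meta to a large group, counted as methoxy in place of trifluoromethyl on an aromatic carbon in full. For the measured compounds named here, the only measured step, a step that the two limits leave unreadable from compound 1 to compound 2 with trifluoromethyl entering, offers no size to carry over. The expected change, a step that the limit leaves unreadable from compound 2 to compound 3 in this assay, is therefore estimated to stay within the scatter, in neither direction. Compound 3 is estimated at 3000 nM with an expected range from 1000 nM to 8000 nM in this reading.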

Compound 3, solubility: < 5000 nM
Compound 3 was reported as a limit (the forecaster's own chance of this, stated with the estimate: 80%); the middle value lies beyond the limit too.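

No step can be read among compound 1, compound 2 and compound 3, because all three sit at one limit: the limit of < 5000 nM in this assay, at which 3 of the 3 values shown sit. The compounds shown leave open whether hydrogen, trifluoromethyl or methoxy on that aromatic carbon makes any difference in this assay at all.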